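The source may hold more compounds than are shown below. What is called first, only, known or untested is meant among the compounds shown, and "the series" means these compounds.

Compound 1 `Cc1c(C(=O)N/N=C/c2ccco2)no[n+]1[O-]` stands at the edge of what can be measured. In an ADME assay on J774.1 cells (Mus musculus) for cytotoxicity, read by MTT assay, with a stated time of 48 h (on this read-out lower numbers stand for stronger inhibition and higher numbers for weaker inhibition), compound 1 gives > 400000 nM, which is a limit of the assay and not a number. Compound 2 `Cc1c(C(=O)N/N=C/c2ccccn2)no[n+]1[O-]` gives in this assay > 400000 nM, also a limit. The step that the two limits leave unreadable from compound 1 to compound 2 is consequently not readable, and the one firm observation is the limit of > 400000 nM in this assay, at which 2 of the 2 values shown sit. Compound 3 `Cc1c(C(=O)N/N=C/c2ccc([N+](=O)[O-])o2)no[n+]1[O-]` differs from compound 1 by nitro in place of hydrogen on an aromatic carbon. Among the measured compounds shown here, no measured step bears on this change, since compound 1 itself sits at the limit. For compound 3 the estimated step is an at least 1.3-fold lower number from compound 1 to compound 3 (0.12 log units; that floor lies within the scatter), and the expected value in this assay is 300000 nM, between 50000 nM and 400000 nM.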

Compound 3, half-maximal inhibitory concentration: 68000 nM
For compound 3 the middle estimate is 4.4-fold (0.64 log units) above the measured one; low and high end bracket the measured number.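

Nitro in place of hydrogen on an aromatic carbon, next to the ring oxygen, moves the series off the limit in this assay, giving an at least 5.8-fold lower number from compound 1 to compound 3 (0.76 log units; beyond the scatter). That size is only a floor, since the entry for compound 1 is a limit and not a number. Of the compounds shown, only compound 3 has left that limit: the limit of > 400000 nM in this assay, at which 2 of the 3 values shown sit.

Going by these compounds, it stays open whether an amine or a carboxylic acid at this position would also give a readable value. On these data alone, it also stays open whether nitro would act alike on the pyridin-2-yl ring of compound 2.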